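Swapping One Aryl Ring on a Shared Core

This account rests on a few compounds, and the source may have more. Where it says the series, first, only, none or still open, it means among the compounds named here.

Compound 3, with the structure `Cc1ccc(-c2nc3sc(Cc4ccc(Cl)cc4)nn3c2Br)cc1`, was tested in an ADME assay on CCRF-CEM cells (Homo sapiens) for cytotoxicity, with a stated time of 72 h; on this read-out lower numbers stand for stronger inhibition and higher numbers for weaker inhibition. In this assay compound 3 gives only a limit, > 250000 nM, not a number. Two relatives share its core. Compound 2, `Fc1ccc(-c2nc3sc(Cc4ccc(Cl)cc4)nn3c2Br)cc1`, also reaches only the limit of > 250000 nM in this assay. Compound 1, `Clc1ccc(Cc2nn3cc(-c4ccc(Cl)cc4Cl)nc3s2)cc1`, likewise returns the limit > 250000 nM in this assay. All three values sit at the limit of > 250000 nM in this assay, at which 3 of the 3 values shown sit. Among the measured compounds shown here, the only single change between measured compounds, a step that the two limits leave unreadable from compound 2 to compound 3, accordingly has a size that cannot be read. Compound 4, `Clc1ccc(Cc2nn3c(Br)c(-c4ccc(Cl)cc4Cl)nc3s2)cc1`, differs from compound 3 by 2,4-dichlorophenyl in place of 4-methylphenyl on an aromatic carbon. For the measured compounds named here, no measured step speaks directly to this change, but compound 1 carries the same 2,4-dichlorophenyl group without the bromo group and stops at the limit. The step of a number no higher from compound 3 to compound 4 (the limit leaves the size open) is therefore expected to be none that can be read beyond the scatter. Compound 4 is expected to show 250000 nM in this assay, within 60000 nM to 1000000 nM, most likely as another limit.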

Compound 4, half-maximal inhibitory concentration: 106000 nM
Estimate against measurement, compound 4: 2.4-fold (0.37 log units) above, within the range that was stated.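

On this aromatic carbon, in this assay, the 2,4-dichlorophenyl group gives a readable change where the bromo group is also present: replacing 4-methylphenyl gives an at least 2.3-fold lower number from compound 3 to compound 4 (0.37 log units; beyond the scatter), and replacing 4-fluorophenyl gives an at least 2.3-fold lower number from compound 2 to compound 4 (0.37 log units; beyond the scatter). The aryl change is not enough alone, since compound 1 carries the same 2,4-dichlorophenyl group without bromo, and adding bromo on the neighbouring aromatic carbon gives an at least 2.3-fold lower number from compound 1 to compound 4 (0.37 log units; beyond the scatter). Among these compounds, only the pairing of both groups in compound 4 moves off the limit, while the other three remain there: the limit of > 250000 nM in this assay, at which 3 of the 4 values shown sit.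

Going by these compounds, it remains open whether both chlorine atoms are needed, as a 4-chlorophenyl group would help to show. Also open, on these data alone, is how an amine or a carboxylic acid in place of the bromo group would behave in this assay.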